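Replacing 2-chlorophenyl with 4-fluorophenyl on a shared core

The compounds below may be only part of what the source reports. "The series", "measured", "known", "first", "only" and "open" are said of these compounds alone.

In an ADME assay on Vero 76 cells (Chlorocebus sabaeus) for cytotoxicity, read by MTT assay, with a stated time of 96 h (on this read-out higher numbers stand for lower toxicity in this test and lower numbers for higher toxicity in this test), compound 1 `NS(=O)(=O)c1ccc(N2N=C(c3ccc(OCc4ccccc4)cc3)CC2c2ccc(F)cc2)cc1` gives 90000 nM, compound 2 `Cc1cccc(C2CC(c3ccc(Oc4ccccc4)cc3)=NN2c2ccc(S(N)(=O)=O)cc2)c1` gives 81000 nM, and compound 3 `NS(=O)(=O)c1ccc(N2N=C(c3ccc(Oc4ccccc4)cc3)CC2c2ccccc2Cl)cc1` gives 29000 nM. Compound 3 therefore has the lowest of the three numbers, and its gaps to the other two lie beyond the usual scatter. The next compound to consider is compound 4 `NS(=O)(=O)c1ccc(N2N=C(c3ccc(Oc4ccccc4)cc3)CC2c2ccc(F)cc2)cc1`, which differs from compound 3 in a single place: 4-fluorophenyl in place of 2-chlorophenyl on a saturated ring carbon. The change sits on a saturated ring carbon, and the core stays the same.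

Going by the values given here, only one measured step touches this same place: a 2.8-fold lower number from compound 2 to compound 3 (0.45 log units; beyond the scatter). That modest step, which brought in the 2-chlorophenyl group, hints that this group goes with a lower number, although a single step is thin evidence. Compound 1, which also carries 4-fluorophenyl at this place, stands at 90000 nM, although the rest of its structure is not the same as in compound 4. Removing 2-chlorophenyl may therefore undo a similar amount, so the expected change in this assay is a 2.2-fold higher number from compound 3 to compound 4 (0.35 log units; beyond the scatter), an estimated modest move to a higher number. For compound 4, the estimated value is 65000 nM, with an expected range from 30000 nM to 100000 nM.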

Compound 4, half-maximal cytotoxic concentration: 25000 nM
For compound 4 the middle estimate is 2.6-fold (0.41 log units) above the measured one; the whole stated range lies above it.
By their numbers in this assay, from the lowest: compounds 4 and 3 (each within the scatter of the next); then compounds 2 and 1 (each within the scatter of the next).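

In this assay, putting 4-fluorophenyl in place of 2-chlorophenyl on the saturated ring carbon gives a 1.2-fold lower number from compound 3 to compound 4 (0.06 log units; within the scatter) and so leaves the read-out effectively unmoved, which means this test does not separate these two groups at this place. With 3-methylphenyl at the same place, the comparison gives a 3.2-fold lower number from compound 2 to compound 4 (0.51 log units; beyond the scatter) as a clear step, so compound 2 now stands apart from both compound 3 and compound 4, and the earlier drop no longer looks specific to 2-chlorophenyl. With 4-fluorophenyl held fixed, the change at the other place, phenyl in place of benzyl on an oxygen on an aromatic ring, gives a 3.6-fold lower number from compound 1 to compound 4 (0.56 log units; beyond the scatter) as a step of its own, so 4-fluorophenyl does not bring the high number of compound 1 by itself.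

Nothing measured here explains why any of these steps has the size it has. Still open, going by these compounds, is whether benzyl on that oxygen would shift the number in the same way with 2-chlorophenyl or 3-methylphenyl on the ring carbon, and how an amine or a carboxylic acid on that phenyl ring would read.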